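The compounds below may be only part of what the source reports. "The series", "measured", "known", "first", "only" and "open" are said of these compounds alone.

Series notes, cytotoxicity. In an ADME assay on Huh-5-2 cells (Homo sapiens) for cytotoxicity, read by WST assay, with a stated time of 3 days (a higher number here means that more compound is tolerated, a lower number that less compound is tolerated), compound 1 `N#Cc1ccccc1COc1cc(O)c2c(=O)c(O)c(-c3ccccc3)oc2c1` gives 22000 nM, compound 2 `O=c1c(O)c(-c2ccccc2)oc2cc(OCc3ccccc3[N+](=O)[O-])cc(O)c12` gives 32000 nM and compound 3 `N#Cc1ccc(COc2cc(O)c3c(=O)c(O)c(-c4ccccc4)oc3c2)cc1` gives 94000 nM. Compound 4 `O=c1c(O)c(-c2ccccc2)oc2cc(OCc3ccc([N+](=O)[O-])cc3)cc(O)c12` has not yet been measured in this assay. The change from compound 1 to compound 2 is nitro in place of cyano on an aromatic carbon, and in this assay it made a 1.5-fold higher number from compound 1 to compound 2 (0.16 log units; within the scatter). The cores of compound 1 and compound 3 differ by 4-cyanophenyl in place of 2-cyanophenyl on a saturated chain carbon bound to an oxygen on an aromatic ring, with a 4.3-fold higher number from compound 1 to compound 3 (0.63 log units; beyond the scatter) and, from compound 2, a 2.9-fold higher number from compound 2 to compound 3 (0.47 log units; beyond the scatter). The change from compound 3 to compound 4 is nitro in place of cyano on an aromatic carbon; it is the same kind of change as that from compound 1 to compound 2, but there the place was ortho to a large group and here it is para to a large group. For compound 4 a step of about a 1.3-fold higher number from compound 3 to compound 4 (0.11 log units; within the scatter) in this assay is expected, resting on the step of a 1.5-fold higher number from compound 1 to compound 2 (0.16 log units; within the scatter). Compound 4 is therefore estimated at 120000 nM, between 50000 nM and 300000 nM.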

Compound 4, half-maximal cytotoxic concentration: 93000 nM
The estimate for compound 4 lay 1.3-fold (0.11 log units) above the measured number; the measured number falls inside the stated range.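

In this assay, the step of a 1.0-fold lower number from compound 3 to compound 4 (0.00 log units; within the scatter) matches the earlier step for nitro in place of cyano: the same change on two cores in this assay, a 1.5-fold higher number (0.16 log units; within the scatter) from compound 1 to compound 2 and a 1.0-fold lower number (0.00 log units; within the scatter) from compound 3 to compound 4, 1.5-fold (0.17 log units) apart, within the scatter of two such steps The change therefore made no step beyond the scatter on either of these two cores, but two pairs do not show that this would hold on other cores. The steps beyond the scatter are a 2.9-fold higher number from compound 2 to compound 4 (0.46 log units; beyond the scatter) and a 4.2-fold higher number from compound 1 to compound 4 (0.63 log units; beyond the scatter); both end at the 4-nitrophenyl compound, and neither is a nitro-for-cyano step on a single core.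

The compounds shown leave open how an amine or a carboxylic acid in place of cyano or nitro would read in this assay. They also leave open whether a longer chain would preserve the numbers seen here.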